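The source may hold more compounds than are shown below. What is called first, only, known or untested is meant among the compounds shown, and "the series" means these compounds.

Compound 1 `C/C1=C\CC[C@@]2(C)O[C@@H]2[C@H]2OC(=O)[C@@H](CN3CCCCC3)[C@@H]2C[C@H]1O`: 7000 nM
Compound 2 `C/C1=C\CC[C@@]2(C)O[C@@H]2[C@H]2OC(=O)[C@@H](CN3CCCC3)[C@@H]2C[C@@H]1O`: 10000 nM

In a functional assay on Hs 683 cells (Homo sapiens) for inhibition, read by colorimetric assay and MTT assay, with a stated time of 72 h (a lower number here means a stronger inhibitor, a higher number a weaker inhibitor), compound 2 and compound 1 lie within the scatter of each other, so the two numbers set no order between them. Compound 3 `C/C1=C\CC[C@@]2(C)O[C@@H]2[C@H]2OC(=O)[C@@H](CN3CCCCC3)[C@@H]2C[C@@H]1O` has piperidin-1-yl in place of pyrrolidin-1-yl on a saturated chain carbon bound to a saturated ring carbon. Going by the values given here, no measured step for this change is available, and no step beyond the scatter is expected in this assay, in either direction. The estimate amounts to an expected 1.3-fold lower number from compound 2 to compound 3 (0.10 log units; within the scatter). The expected value for compound 3 is 8000 nM, with an estimated range from 3500 nM to 18000 nM.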

Compound 3, half-maximal inhibitory concentration: 7000 nM
The estimate for compound 3 lay 1.1-fold (0.06 log units) above the measured number, and the stated range covers the measured number.
By their numbers in this assay, from the lowest: compounds 1, 3 and 2 (each within the scatter of the next).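

In this assay, piperidin-1-yl in place of pyrrolidin-1-yl on a saturated chain carbon bound to a saturated ring carbon gives a 1.4-fold lower number from compound 2 to compound 3 (0.15 log units; within the scatter), so these two rings set no order at this position. Inverting one saturated ring stereocentre gives no change at the digits printed from compound 1 to compound 3 (within the scatter), so this configuration sets no order either. That reading isolates the stereocentre, and it rests on one fact: the fact that compounds 1 and 3 differ only in the configuration as drawn

The compounds shown leave open whether morpholin-4-yl or an open-chain dimethylamino group at this position would read differently in this assay.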